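From an Alkylamino Group to a Sulfonyloxy Group

A few compounds are considered here, and "the series" means these few. Any claim that something is new, unique, unknown or untested is made for them only; others in the source may bear on it.

Measured compounds:
compound 1 `COC(=O)CNc1c(C(=O)NCc2ccc(F)cc2)nc(Br)c2cccnc12` — a limit of the assay, > 10000 nM
compound 2 `CNCCCNc1c(C(=O)NCc2ccc(F)cc2)nc(Br)c2cccnc12` — 9000 nM

Among the measured compounds shown here, in a functional assay on HCT-116 cells (Homo sapiens) for cytotoxicity, read by MTT assay, with a stated time of 72 h (a higher number here means a weaker inhibitor, a lower number a stronger inhibitor), compound 2 gives 9000 nM, the only number obtained. Compound 1 reaches only a limit of the assay, > 10000 nM, as noted in the limit of > 10000 nM in this assay, at which 1 of the 2 values shown sits. For the measured compounds named here, the one measured step, an at least 1.1-fold lower number from compound 1 to compound 2 (0.04 log units; that floor lies within the scatter), therefore shows only that the two compounds sit close together at the weak end of the assay.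

Compound 3 `Cc1ccc(S(=O)(=O)Oc2c(C(=O)NCc3ccc(F)cc3)nc(Br)c3cccnc23)cc1` changes the same position once more: ((4-methylphenyl)sulfonyl)oxy in place of (3-(methylamino)propyl)amino on an aromatic carbon. Going by the values given here, no measured step involves either a sulfonyloxy group or the removal of the saturated chain, so the step from compound 1 to compound 2 bears on it only by showing how little movement a change at this position produced there. Given that, compound 3 is expected to remain weak in this assay, with a step of a 1.3-fold higher number from compound 2 to compound 3 (0.12 log units; within the scatter) that may not exceed the scatter. The estimate for compound 3 is 12000 nM, within a range from 3000 nM to 50000 nM, with a real chance that only a limit is reported.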

Compound 3, half-maximal inhibitory concentration: > 20000 nM
Compound 3 gave a limit, no number; the forecaster's own chance of this, stated with the estimate: 55%; at least 1.6-fold (0.22 log units) between middle value and limit.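

Setting ((4-methylphenyl)sulfonyl)oxy in place of (3-(methylamino)propyl)amino on this aromatic carbon gives an at least 2.2-fold higher number from compound 2 to compound 3 (0.34 log units; beyond the scatter) in this assay, so a change at this position now moves the result beyond the scatter, which the earlier step within the chain did not show. On these data alone, the true size of that step stays open, and compound 3 marks only a limit of the assay, not a number: the limit of > 20000 nM in this assay, at which 1 of the 3 values shown sits. The step between compound 1 and compound 3 cannot be read, so ((4-methylphenyl)sulfonyl)oxy cannot be placed in order against ((methoxycarbonyl)methyl)amino.

The compounds shown leave open whether the step comes from the departure of the (3-(methylamino)propyl)amino group or from the arrival of the ((4-methylphenyl)sulfonyl)oxy group, as the change does both at once. A hydroxyl group or a plain amino group on this aromatic carbon, or a longer chain ending in a dimethylamino group, would be needed to separate the two and to show whether any group here gives a clearly lower number in this assay.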